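The source may hold more compounds than are shown below. What is called first, only, known or untested is meant among the compounds shown, and "the series" means these compounds.

Compounds measured so far:
Compound 1, `C#CCCCn1c(Cc2cc(OC)c(OC)c(OC)c2)nc2c(N)ncnc21`, gives 24000 nM in a functional assay on MCF7 cells (Homo sapiens) for antiproliferative activity; a lower number here means a stronger inhibitor, a higher number a weaker inhibitor.
Compound 2, `COc1cc(Cc2nc3c(N)ncnc3n2CC2CCCO2)cc(OC)c1OC`, gives 91200 nM in this assay.
Compound 3, `CCCCCn1c(Cc2cc(OC)c(OC)c(OC)c2)nc2c(N)nc(F)nc21`, gives 36300 nM in this assay.

Compound 3 holds the second highest of the three numbers. Its closest neighbour is compound 1, whose number is lower, but the gap between the two lies within the scatter, so no order between compound 1 and compound 3 can be read from these values. Compound 2 sits furthest away, with a number higher than that of compound 3 by a margin beyond the scatter.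

Compound 4, `CCCCCn1c(Cc2cc(OC)c(OC)c(OC)c2)nc2c(N)ncnc21`, differs from compound 3 in one place: hydrogen in place of fluoro on an aromatic carbon. The change sits on an aromatic carbon between two ring nitrogen atoms of the shared core, meta to the amino group.

For the measured compounds named here, the only measured step, a 3.8-fold higher number from compound 1 to compound 2 (0.58 log units; beyond the scatter), concerns a different position and a different kind of group and so says nothing about the loss of fluoro. Going by the values given here, no measured pair tells how the fluoro on this carbon affects the number. In the absence of such a step, compound 4 is expected to give a number close to that of compound 3, with the step of a 1.2-fold lower number from compound 3 to compound 4 (0.08 log units; within the scatter) estimated to stay within the scatter. Compound 4 is therefore estimated at 30000 nM, with a range from 12000 nM to 80000 nM.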

Compound 4, half-maximal inhibitory concentration: 61700 nM
The estimate for compound 4 lay 2.1-fold (0.31 log units) below the measured number; the measured number falls inside the stated range.
By their numbers in this assay, from the lowest: compounds 1, 3, 4 and 2 (each within the scatter of the next, the first and the last beyond it).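

In this assay, hydrogen in place of fluoro on the aromatic carbon between two ring nitrogen atoms gives a 1.7-fold higher number from compound 3 to compound 4 (0.23 log units; within the scatter), so this pair shows no effect of the change at this position that can be told apart from the scatter. For the compounds shown here, compound 4 also gives the first direct readings of the chain on the aromatic nitrogen at a fixed core: butyl in place of oxolan-2-yl gives a 1.5-fold lower number from compound 2 to compound 4 (0.17 log units; within the scatter), which cannot be ordered, whereas ethyl in place of ethynyl gives a 2.6-fold higher number from compound 1 to compound 4 (0.41 log units; beyond the scatter), so the ethynyl-ended chain of compound 1 stands apart from the pentyl chain of compound 4 by a modest margin. No evidence is available that would explain any of these steps.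

The compounds shown leave open whether chloro, an amine or a methyl on this same aromatic carbon would stand apart from hydrogen and fluoro, since only those two groups have been compared there. They also leave open how a longer chain, or a chain ending in a carboxylic acid, on the aromatic nitrogen would compare with the pentyl chain of compound 4.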